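Replacing Furan-2-yl by 3-Hydroxyphenyl: Compound 1 to Compound 4

The compounds below may be only part of what the source reports. "The series", "measured", "known", "first", "only" and "open" are said of these compounds alone.

Compound 1 `CC(=O)N1N=C(c2cc(O)c(O)c([N+](=O)[O-])c2)CC1c1ccco1` was tested in an assay on isolated protein for inhibition of Amine oxidase [flavin-containing] B (Homo sapiens), read by fluorescence (a higher number here means a weaker inhibitor, a lower number a stronger inhibitor), where compound 1 gives 77400 nM. This is the highest of the three numbers recorded, yet both neighbours sit within the scatter: compound 2 `N#Cc1ccc(/C=C/C(=O)c2cc(O)c(O)c([N+](=O)[O-])c2)cc1` gives 56600 nM in this assay, and compound 3 `O=C(/C=C/c1cccs1)c1cc(O)c(O)c([N+](=O)[O-])c1` gives 62900 nM. No two of these compounds differ in a single place, so no step can be read from them. Compound 4 `CC(=O)N1N=C(c2cc(O)c(O)c([N+](=O)[O-])c2)CC1c1cccc(O)c1` differs from compound 1 by 3-hydroxyphenyl in place of furan-2-yl on a saturated ring carbon. Nothing measured here speaks to this exchange, and the three values lie close together, so no step beyond the scatter is expected. The step from compound 1 to compound 4 is estimated at a 1.2-fold lower number from compound 1 to compound 4 (0.08 log units; within the scatter). Compound 4 is expected to give 65000 nM in this assay, within 22000 nM to 190000 nM.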

Compound 4, half-maximal inhibitory concentration: 85200 nM
For compound 4 the middle estimate is 1.3-fold (0.12 log units) below the measured one; the measured number falls inside the stated range.
By their numbers in this assay, from the lowest: compounds 2, 3, 1 and 4 (each within the scatter of the next).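

In this assay, 3-hydroxyphenyl in place of furan-2-yl on this saturated ring carbon gives a 1.1-fold higher number from compound 1 to compound 4 (0.04 log units; within the scatter). This first single-place exchange shows that a six-membered aromatic ring of carbon only, carrying a hydrogen-bond donor, can replace a five-membered aromatic ring with one hetero atom here without a step beyond the scatter. No measured property bears on this result.

From the compounds shown here alone, whether an amine or a carboxylic acid on this ring carbon would give a step beyond the scatter remains open. So does the effect of replacing the acetyl group on the neighbouring ring atom with a longer chain.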